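Chloro for fluoro on a para-substituted aryl piperidine core

The source may report more compounds than this note shows. Statements on the series, on what has been measured and on what is new or still open speak of the compounds shown alone.

Compound 1 `Cc1ccc(-c2n[nH]c3c2CCNCC3)cc1` gives 97.4% in a functional assay on HEK293 cells for antagonist activity at 5-hydroxytryptamine receptor 7 (Homo sapiens), read by luminescence and cAMP accumulation; a lower number here means a smaller maximal response, a higher number a larger maximal response. Compound 2 `Fc1ccc(-c2n[nH]c3c2CCNCC3)cc1` gives 98.4%. Compound 3 `Cc1ccc(-c2noc3c2CCNCC3)cc1` gives 95.8%.

All three numbers sit close together, and compound 2 lies within the scatter of both compound 1 and compound 3, so none of them can be set apart from the others. Compound 4 `Clc1ccc(-c2n[nH]c3c2CCNCC3)cc1` carries a single alteration relative to compound 2: chloro in place of fluoro on an aromatic carbon. For the measured compounds named here, the one measured step that touches the same place, a number 1 percentage points higher from compound 1 to compound 2 (within the scatter), stayed within the scatter, and swapping one small halogen for another is a change of the same kind. No step beyond the scatter is therefore expected in this assay, and compound 4 is estimated at 97% (range 90% to 103%). The expected step is a number 1.4 percentage points lower from compound 2 to compound 4 (within the scatter).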

Compound 4, largest response reached (reported as Imax), in percent of the reference or control that the assay uses: 94.8%
The estimate for compound 4 lay 2.2 percentage points above the measured number; the measured number falls inside the stated range.
By their numbers in this assay, from the lowest: compounds 4, 3, 1 and 2 (each within the scatter of the next).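

In this assay, chloro now joins fluoro and methyl on the aromatic carbon para to a large group. Chloro in place of fluoro gives a number 3.6 percentage points lower from compound 2 to compound 4 (within the scatter), and chloro in place of methyl gives a number 2.6 percentage points lower from compound 1 to compound 4 (within the scatter), so these three groups cannot be told apart at this position in this read-out. No evidence is available on what lies behind this result. Still open, going by these compounds, is whether an amine, a carboxylic acid or a longer chain on this carbon would give a step beyond the scatter.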